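This account rests on a few compounds, and the source may have more. Where it says the series, first, only, none or still open, it means among the compounds named here.

In an ADME assay on liver for metabolic stability, with Liver microsome (Homo sapiens) as the target, read by LC-MS, using microsomes (on this read-out higher numbers stand for fast clearance and lower numbers for slow clearance), compound 3 (`CC(C)(C)[C@@H](O)C(=O)N1N=CC[C@H]1C(=O)NCc1cc(Cl)ccc1-n1cnnn1`) gives < 12 mL.min-1.g-1 as a limit of the assay and not a number. Compound 1 (`O=C(NCc1cc(Cl)ccc1-n1cnnn1)[C@@H]1CC=NN1C(=O)[C@H](O)c1ccccc1`) gives < 12 mL.min-1.g-1 as a limit too. Compound 2 (`CC1(C[C@@H](O)C(=O)N2N=CC[C@H]2C(=O)NCc2cc(Cl)ccc2-n2cnnn2)CC1`) also gives < 12 mL.min-1.g-1 as a limit. What the three show so far is the limit of < 12 mL.min-1.g-1 in this assay, at which 3 of the 3 values shown sit, and nothing finer. Compound 4 (`COC(C)(C)[C@@H](O)C(=O)N1N=CC[C@H]1C(=O)NCc1cc(Cl)ccc1-n1cnnn1`) differs from compound 3 by methoxy in place of methyl on a saturated chain carbon bound to three saturated chain carbons. Two measured steps change this same side chain, a step that the two limits leave unreadable from compound 1 to compound 3 and a step that the two limits leave unreadable from compound 2 to compound 3, and neither offers a size to build on. The expected step is a step that the limit leaves unreadable from compound 3 to compound 4 and it is not expected to exceed the usual scatter in either direction. For compound 4 the estimated clearance is 9 mL.min-1.g-1 (range 5 mL.min-1.g-1 to 18 mL.min-1.g-1).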

Compound 4, intrinsic clearance in microsomes: < 12 mL.min-1.g-1
Compound 4: no number, only a limit; the forecaster's own chance of this, stated with the estimate: 70%; the middle value is on the limit's open side.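

Compound 4 gives only a limit, as do compound 1, compound 2 and compound 3, so no step among them can be read: the limit of < 12 mL.min-1.g-1 in this assay, at which 4 of the 4 values shown sit.

The compounds shown leave open how far apart their actual clearances lie, and whether methoxy in place of methyl changes clearance at all.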